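The source may report more compounds than this note shows. Statements on the series, on what has been measured and on what is new or still open speak of the compounds shown alone.

In an ADME assay on MT4 cells (Homo sapiens) for cytotoxicity, read by MTT assay, with a stated time of 5 days (on this read-out higher numbers stand for lower toxicity in this test and lower numbers for higher toxicity in this test), compound 1 `COc1cc2nc(SCC(=O)Nc3ccc(C(F)(F)F)cc3)nc(Nc3c(C)cc(/C=C/C#N)cc3C)c2cc1OC` gives > 211000 nM as a limit and not a number. Compound 2 `COc1cc2nc(SCC(=O)Nc3cccc(Cl)c3)nc(Nc3c(Cl)cc(/C=C/C#N)cc3Cl)c2cc1OC` gives > 208000 nM as a limit too. Compound 3 `COc1cc2nc([S+]([O-])CC(=O)Nc3ccccc3[N+](=O)[O-])nc(Nc3c(Cl)cc(/C=C/C#N)cc3Cl)c2cc1OC` gives > 199000 nM as a limit as well. Compound 3 therefore has no exact value, and neither do the other two, so it cannot be ranked against them.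

Compound 4 `COc1cc2nc([S+]([O-])CC(=O)Nc3ccc([N+](=O)[O-])cc3)nc(Nc3c(Cl)cc(/C=C/C#N)cc3Cl)c2cc1OC` differs from compound 3 in one place: 4-nitrophenyl in place of 2-nitrophenyl on an amide-type nitrogen puts 4-nitrophenyl in place of 2-nitrophenyl on an amide-type nitrogen. Within the data shown here, no measured pair shows the size of such a change. The expected step of a number no higher from compound 3 to compound 4 (the limit leaves the size open) stays within the usual scatter, resting only on compound 3 with its limit of > 199000 nM as the starting point. For compound 4 the estimate is 199000 nM within an expected range from 100000 nM to 300000 nM and quite possibly reported as a limit again.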

Compound 4, half-maximal cytotoxic concentration: 92800 nM
Estimate against measurement, compound 4: 2.1-fold (0.33 log units) above; the whole stated range lies above it.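

Placing 4-nitrophenyl in place of 2-nitrophenyl on the amide-type nitrogen gives, in this assay, an at least 2.1-fold lower number from compound 3 to compound 4 (0.33 log units; beyond the scatter), so the same atoms joined differently are enough to shift this read-out toward higher toxicity. Among these compounds, compound 4 is also the first compound here with an exact number rather than a limit. Compound 3 has only a limit, so the size of the step stays open: the limit of > 199000 nM in this assay, at which 1 of the 4 values shown sits.

Still open is why the nitro group's place on this ring matters. It is also unknown how an amine or a carboxylic acid on the same ring would read.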